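Dropping the chlorophenoxy ring from a weak thiadiazole series

A few compounds are considered here, and "the series" means these few. Any claim that something is new, unique, unknown or untested is made for them only; others in the source may bear on it.

Compounds measured so far, in a functional assay on Huh-7 cells (Homo sapiens) for inhibition, read by MTT assay, with a stated time of 48 h; on this read-out higher numbers stand for weaker inhibition and lower numbers for stronger inhibition:
Compound 1 `Cc1nnsc1CO/N=C/c1c(C)nn(C)c1Oc1cccc(C(F)(F)F)c1` gives > 50000 nM, which is a limit of the assay and not a number.
Compound 2 `Cc1nnsc1CO/N=C/c1c(C)nn(C)c1Oc1ccc(Br)cc1` gives 11800 nM.
Compound 3 `CCCc1nnsc1CO/N=C/c1c(C)nn(C)c1Oc1ccc(Cl)cc1` gives > 50000 nM, again a limit of the assay rather than a number.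

Compound 3 therefore sits at the limit of > 50000 nM in this assay, at which 2 of the 3 values shown sit, so where it truly stands is not known beyond that. Compound 4 `CCCc1nnsc1CO/N=C/c1c(C)nn(C)c1Cl` differs from compound 3 in one place: chloro in place of 4-chlorophenoxy on an aromatic carbon. Among the measured compounds shown here, no measured pair shows this kind of change, so no direction or size can be drawn from the data; the expectation is only that compound 4 stays near the same limit, with no step beyond the scatter. Compound 4 is thus estimated at 60000 nM, within 15000 nM to 200000 nM, which is an expected step that the limit leaves unreadable from compound 3 to compound 4.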

Compound 4, half-maximal inhibitory concentration: > 50000 nM
Compound 4 gave a limit, no number; the forecaster's own chance of this, stated with the estimate: 75%; the middle value is on the limit's open side.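

Among the compounds shown here, compound 3 and compound 4 both give a limit of the assay and not a number, so no step between them can be read: the limit of > 50000 nM in this assay, at which 3 of the 4 values shown sit. Going by these compounds, whether chloro in place of 4-chlorophenoxy changes inhibition at all stays open.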